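The source may report more compounds than this note shows. Statements on the series, on what has been measured and on what is new or still open speak of the compounds shown alone.

The series shares one core, carried in compound 1 `O=C(CN1CCN(c2cc3c(cc2F)c(=O)c(C(=O)O)cn3C2CC2)CC1)Nc1ccc(C(=O)/C=C/c2ccccc2)cc1`, compound 2 `O=C(CN1CCN(c2cc3c(cc2F)c(=O)c(C(=O)O)cn3C2CC2)CC1)Nc1ccc(C(=O)/C=C/c2ccccc2Cl)cc1` and compound 3 `COc1ccc(/C=C/C(=O)c2ccc(NC(=O)CN3CCN(c4cc5c(cc4F)c(=O)c(C(=O)O)cn5C4CC4)CC3)cc2)cc1`; compound 4 `COc1ccc(/C=C/C(=O)c2ccc(NC(=O)CN3CCN(c4cc5c(cc4F)c(=O)c(C(=O)O)cn5C4CC4)CC3)cc2)cc1OC` has not yet been measured. In a physicochemical assay for solubility, at pH 6.9 (a lower number here means a less soluble compound, a higher number a more soluble compound), compound 1 gives 2.73 ug/mL, compound 2 gives 2.45 ug/mL and compound 3 gives 2.98 ug/mL. The three numbers sit close together: a 1.1-fold lower number from compound 1 to compound 2 (0.05 log units; within the scatter), a 1.1-fold higher number from compound 1 to compound 3 (0.04 log units; within the scatter) and a 1.2-fold higher number from compound 2 to compound 3 (0.09 log units; within the scatter), so compound 3 stands within the scatter of both other compounds in this assay.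

The change from compound 3 to compound 4 is methoxy in place of hydrogen on an aromatic carbon. Going by the values given here, the one earlier step of the same kind is the methoxy added on an aromatic carbon, a 1.1-fold higher number from compound 1 to compound 3 (0.04 log units; within the scatter), which did not leave the scatter, and the swap of one aryl group for another, a 1.2-fold higher number from compound 2 to compound 3 (0.09 log units; within the scatter), was equally small. On this basis compound 4 is expected to show no step beyond the scatter, a 1.0-fold higher number from compound 3 to compound 4 (0.00 log units; within the scatter). Compound 4 is therefore estimated at 3 ug/mL in this assay, with a range from 1.5 ug/mL to 6 ug/mL.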

Compound 4, solubility: 0.75 ug/mL
Compound 4: middle estimate off by 4.0-fold (0.60 log units), on the high side, outside the stated range (below it).
By their numbers in this assay, from the lowest: compound 4; then compounds 2, 1 and 3 (each within the scatter of the next).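

In this assay, adding a methoxy on an aromatic carbon is no longer a change without effect: placed ortho to a methoxy group and meta to a large group, it gives a 4.0-fold lower number from compound 3 to compound 4 (0.60 log units; beyond the scatter), whereas the earlier methoxy stayed within the scatter (a 1.1-fold higher number from compound 1 to compound 3 (0.04 log units; within the scatter)). Compared as whole groups, 3,4-dimethoxyphenyl also stands apart from phenyl (a 3.6-fold lower number from compound 1 to compound 4 (0.56 log units; beyond the scatter)) and from 2-chlorophenyl (a 3.3-fold lower number from compound 2 to compound 4 (0.51 log units; beyond the scatter)), so this aryl group is the first of the series to move the number beyond the scatter. Nothing available accounts for this lower number.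

On these data alone, it remains open whether a methoxy at this place gives a step of this size with no methoxy ortho to it. As far as these compounds go, how a hydroxy group or an amine at the same place would read in this assay also remains open.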